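From thiophen-3-yl to phenyl in a pair at the limit

The source may hold more compounds than are shown below. What is called first, only, known or untested is meant among the compounds shown, and "the series" means these compounds.

Compound 1 `COc1ncnc2c1c(-c1ccccc1)cn2[C@@H]1O[C@H](CO)[C@@H](O)[C@H]1O` and compound 2 `COc1nc(N)nc2c1c(-c1ccsc1)cn2[C@@H]1O[C@H](CO)[C@@H](O)[C@H]1O` share a core and were both tested in a functional assay on CCRF-CEM cells (Homo sapiens), read by MTT assay, with a stated time of 72 h; a lower number here means a stronger inhibitor, a higher number a weaker inhibitor. In this assay compound 1 gives > 20000 nM, which is a limit and not a number. In this assay compound 2 gives > 20000 nM, which is also a limit. Compound 2 thus stands at the limit of > 20000 nM in this assay, at which 2 of the 2 values shown sit. Compound 3 `COc1nc(N)nc2c1c(-c1ccccc1)cn2[C@@H]1O[C@H](CO)[C@@H](O)[C@H]1O` carries phenyl in place of thiophen-3-yl on an aromatic carbon. The expected step is a number no higher from compound 2 to compound 3 (the limit leaves the size open), with no change beyond the usual scatter. For compound 3 the estimate is 20000 nM, with an expected range from 8000 nM to 40000 nM.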

Compound 3, half-maximal inhibitory concentration: > 20000 nM
Compound 3 ended at the assay's limit; the forecaster's own chance of this, stated with the estimate: 75%; the middle value sits exactly at the limit.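

No step to compound 3 from compound 1 or compound 2 can be read in this assay, since all three stand at one limit: the limit of > 20000 nM in this assay, at which 3 of the 3 values shown sit.

From the compounds shown here alone, whether phenyl in place of thiophen-3-yl, or amino in place of hydrogen, changes the inhibition at all stays open.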